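Varying the amide end of a nitrobenzofurazan thioether series

The compounds below may be only part of what the source reports. "The series", "measured", "known", "first", "only" and "open" are said of these compounds alone.

Measured so far:
Compound 1, `O=C(CCC(=O)OCCCCCCSc1ccc([N+](=O)[O-])c2nonc12)Nc1cccc(Cl)c1`: 2890 nM
Compound 2, `O=C(CCC(=O)OCCCCCCSc1ccc([N+](=O)[O-])c2nonc12)Nc1ccc(Br)cc1`: 2710 nM
Compound 3, `COc1ccc(NC(=O)CCC(=O)OCCCCCCSc2ccc([N+](=O)[O-])c3nonc23)cc1`: 3060 nM

All three compounds share the same core and differ only in the aryl group on the amide-type nitrogen. In a functional assay on 143B cells (Homo sapiens) for inhibition, read by MTT assay, with a stated time of 72 h (a lower number here means a stronger inhibitor, a higher number a weaker inhibitor), compound 3 gives 3060 nM, the highest of the three numbers, but its nearest neighbour is compound 1 and the gap is a 1.1-fold higher number from compound 1 to compound 3 (0.02 log units; within the scatter), while against compound 2 it is a 1.1-fold higher number from compound 2 to compound 3 (0.05 log units; within the scatter); the third pair shows a 1.1-fold lower number from compound 1 to compound 2 (0.03 log units; within the scatter). No two of the measured compounds can therefore be told apart in this assay.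

Compound 4, `O=C(CCC(=O)N1CCCCC1)OCCCCCCSc1ccc([N+](=O)[O-])c2nonc12`, is not yet measured. It differs from compound 3 by piperidin-1-yl in place of (4-methoxyphenyl)amino on a carbonyl carbon. For the measured compounds named here, none of the measured steps bears on this change: each of them only exchanges one aryl group for another on the amide-type nitrogen, and none removes the aryl amide altogether, so the measured steps only show that the aryl substituent itself made no difference beyond the scatter.

Going by the values given here, with no step of this kind measured, compound 4 is expected to give 3500 nM in this assay, with a wide range of 1400 nM to 9000 nM. That estimate corresponds to an expected step of a 1.1-fold higher number from compound 3 to compound 4 (0.06 log units; within the scatter), and is built mainly on the fact that the measured values of compound 1, compound 2 and compound 3 all lie close together.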

Compound 4, half-maximal inhibitory concentration: 1900 nM
Estimate against measurement, compound 4: 1.8-fold (0.27 log units) above; the measured number falls inside the stated range.
By their numbers in this assay, from the lowest: compounds 4, 2, 1 and 3 (each within the scatter of the next).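

Compound 4 is the first compound shown that drops the aryl amide altogether: piperidin-1-yl on the carbonyl carbon brings a non-aromatic ring and 0 hydrogen-bond donors, where (4-methoxyphenyl)amino carried an aromatic ring and 1 hydrogen-bond donor. Even so, in this assay the readings are a 1.6-fold lower number from compound 3 to compound 4 (0.21 log units; within the scatter) and a 1.4-fold lower number from compound 2 to compound 4 (0.15 log units; within the scatter) and a 1.5-fold lower number from compound 1 to compound 4 (0.18 log units; within the scatter), so compound 4 cannot be told apart from any of the three aryl amides, and at this position neither the aromatic ring nor the amide hydrogen is shown to be needed for a number in this range. No measured information on how these compounds act is available to account for this result.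

The compounds shown leave open whether any group on this carbonyl carbon can shift the number beyond the scatter, for example a morpholine ring, a dimethylamino group or a free carboxylic acid in place of the amide. On these data alone, all four compounds also keep the same chain and the same core, so what a longer chain or a shorter one would do remains open.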